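Carbonyl substituent variation on a shared core

A few compounds are considered here, and "the series" means these few. Any claim that something is new, unique, unknown or untested is made for them only; others in the source may bear on it.

Compound 1 `Cc1nc(S(C)(=O)=O)ccc1Oc1ncnc(OC2CCN(C(=O)OC3CCC3)CC2)c1F`: 13.6 nM
Compound 2 `Cc1nc(S(C)(=O)=O)ccc1Oc1ncnc(OC2CCN(C(=O)SC(C)(C)C)CC2)c1F`: 4.83 nM
Compound 3 `Cc1nc(S(C)(=O)=O)ccc1Oc1ncnc(OC2CCN(C(=O)SC3CC3)CC2)c1F`: 24.9 nM

In a functional assay on isolated protein for inhibition of Glucose-dependent insulinotropic receptor (Homo sapiens), read by HTRF and cAMP accumulation (a higher number here means that more compound is needed for the effect, a lower number that less compound is needed), compound 3 gives the highest of the three numbers; its step to compound 1 lies within the scatter, while the step from compound 2 to compound 3 is a 5.2-fold higher number from compound 2 to compound 3 (0.71 log units; beyond the scatter). Compound 4 `Cc1nc(S(C)(=O)=O)ccc1Oc1ncnc(OC2CCN(C(=O)C3(C)CC3)CC2)c1F` differs from compound 3 by a group of 4 heavy atoms (4 carbon; one three-membered non-aromatic ring of carbon only) in place of a group of 4 heavy atoms (3 carbon, 1 sulfur; one three-membered non-aromatic ring of carbon only), on a carbonyl carbon. Among the measured compounds shown here, no measured step swaps sulfur for carbon at this carbonyl, so the relevant evidence is indirect: a 1.8-fold higher number from compound 1 to compound 3 (0.26 log units; within the scatter) and a 5.2-fold higher number from compound 2 to compound 3 (0.71 log units; beyond the scatter) show that changes at this carbonyl move this assay only modestly. A small step is therefore expected, a 1.7-fold lower number from compound 3 to compound 4 (0.22 log units; within the scatter), slightly toward a lower number. Compound 4 is estimated at 15 nM, with a range from 5 nM to 50 nM.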

Compound 4, half-maximal effective concentration: 761 nM
Estimate against measurement, compound 4: 51-fold (1.71 log units) below, outside the stated range (above it).
By their numbers in this assay, from the lowest: compound 2; then compounds 1 and 3 (each within the scatter of the next); then compound 4.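

In this assay 1-methylcyclopropyl on the carbonyl carbon gives a 31-fold higher number from compound 3 to compound 4 (1.49 log units; beyond the scatter) and a 160-fold higher number from compound 2 to compound 4 (2.20 log units; beyond the scatter) and a 56-fold higher number from compound 1 to compound 4 (1.75 log units; beyond the scatter) in this set. Compound 1, compound 2 and compound 3, which carry oxygen or sulfur on the carbonyl, differ far less among themselves, so this position proves much more sensitive than they suggested, even though compound 4 keeps the three-membered carbon ring and heavy-atom count of compound 3. No measurement shown accounts for this jump. Still open, as far as these compounds go, is whether the step follows the lost sulfur or the added ring methyl, and how an amine nitrogen on this carbonyl would read.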